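From phenyl to pyridin-4-yl on compound 1

This account rests on a few compounds, and the source may have more. Where it says the series, first, only, none or still open, it means among the compounds named here.

Compound 1 `Nc1ccccc1NC(=O)c1ccc(CSC(=S)N2CCN(c3ccccc3)CC2)cc1`: 840 nM
Compound 2 `Nc1ccccc1NC(=O)c1ccc(CSC(=S)N2CCc3ccccc32)cc1`: 3450 nM

In a functional assay on HeLa cells (Homo sapiens) for antiproliferative activity, read by CCK-8 assay, with a stated time of 72 h (on this read-out higher numbers stand for weaker inhibition and lower numbers for stronger inhibition), compound 1 holds the lower of the two numbers, which marks the stronger inhibition, and compound 2 stands higher, beyond the scatter. Compound 3 `Nc1ccccc1NC(=O)c1ccc(CSC(=S)N2CCN(c3ccncc3)CC2)cc1` carries pyridin-4-yl in place of phenyl on an amine nitrogen in a ring. Within the data shown here, no measured pair of compounds shows this change, so only a small estimated step of a 1.3-fold higher number from compound 1 to compound 3 (0.12 log units; within the scatter) toward a higher number is expected, not beyond the scatter. Compound 3 is estimated at 1100 nM (350 nM to 3500 nM).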

Compound 3, half-maximal inhibitory concentration: 790 nM
The estimate for compound 3 lay 1.4-fold (0.14 log units) above the measured number; the range from low to high includes it.
By their numbers in this assay, from the lowest: compounds 3 and 1 (each within the scatter of the next); then compound 2.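

In this assay, replacing phenyl with pyridin-4-yl on an amine nitrogen in a ring gives a 1.1-fold lower number from compound 1 to compound 3 (0.03 log units; within the scatter). This single-place step, which the earlier pair could not provide, shows that adding a ring nitrogen and a hydrogen-bond acceptor at this position leaves the number within the scatter. Nothing available here indicates why the two groups read alike. The compounds shown leave open whether pyridin-2-yl or pyridin-3-yl would read the same here. They also leave open how a phenyl bearing a carboxylic acid or an amine would read at this position.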